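The source may hold more compounds than are shown below. What is called first, only, known or untested is meant among the compounds shown, and "the series" means these compounds.

In a functional assay on the whole organism for inhibition, with Scenedesmus acutus as the target (on this read-out lower numbers stand for stronger inhibition and higher numbers for weaker inhibition), compound 1 `COC(=O)c1cc(N2C(=O)C3=C(CCCC3)C2=O)c(F)cc1Cl` gives 67.6 nM and compound 2 `CCOC(=O)c1cc(N2C(=O)C3=C(CCCC3)C2=O)c(F)cc1Cl` gives 57.5 nM. Compound 3 `CCOC(=O)c1cc(N2C(=O)C3=C(CCCC3)C2=O)ccc1Cl` gives 1910 nM, the highest number of the three and so the weakest inhibition so far.

The next structure, compound 4 `C#CCOc1cc(N2C(=O)C3=C(CCCC3)C2=O)ccc1Cl`, keeps the shared core and the chloro group. On an aromatic carbon, ortho to that chloro group, propargyloxy takes the place of ethoxycarbonyl: propargyloxy in place of ethoxycarbonyl on an aromatic carbon.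

Going by the values given here, two measured steps bear on this only partly. Lengthening the ester gave a 1.2-fold lower number from compound 1 to compound 2 (0.07 log units; within the scatter), so that small edit to the group now leaving changed little. Losing the fluoro gave a 33-fold higher number from compound 2 to compound 3 (1.52 log units; beyond the scatter), a large step. Compound 4 also lacks that fluoro, which suggests it will not return to the level of the first two compounds.

Among the compounds with values here, no measured pair swaps ethoxycarbonyl for propargyloxy, so the direction is a judgement with little support. A modest move toward stronger inhibition seems more likely than a further loss, given that compound 3 at 1910 nM already sits at the top of the range. The expected change is a 2.7-fold lower number from compound 3 to compound 4 (0.44 log units; beyond the scatter).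

For compound 4 the estimate is 700 nM, with an expected range from 120 nM to 3000 nM.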

Compound 4, half-maximal inhibitory concentration: 100 nM
Compound 4: the middle estimate sits 7.0-fold (0.85 log units) above what was measured; measured number outside the range, below it.
By their numbers in this assay, from the lowest: compounds 2, 1 and 4 (each within the scatter of the next); then compound 3.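

In this assay, replacing ethoxycarbonyl with propargyloxy, ortho to the chloro group, gives a 19-fold lower number from compound 3 to compound 4 (1.28 log units; beyond the scatter), so an ester is not needed at this position for a low number. The earlier change to this group only lengthened the ester and gave a 1.2-fold lower number from compound 1 to compound 2 (0.07 log units; within the scatter), whereas replacing the whole group shifts the number far beyond the scatter, which makes this position much more responsive than that first step suggested. The swap also replaces a group with 2 hydrogen-bond acceptors and a double bond with one that has 1 hydrogen-bond acceptor and a triple bond, but no measurement here explains why the number falls.

Going by these compounds alone, the fluoro step, a 33-fold higher number from compound 2 to compound 3 (1.52 log units; beyond the scatter), was seen only with ethoxycarbonyl in place, so it remains open whether restoring fluoro on compound 4 would lower the number further or change little. Also open, on these data alone, is how this position would respond to a saturated propoxy chain, which would show whether the triple bond matters, or to quite different groups such as an amine or a carboxylic acid.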